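From butyl to cyclopentyl on the sulfur

A few compounds are considered here, and "the series" means these few. Any claim that something is new, unique, unknown or untested is made for them only; others in the source may bear on it.

In an ADME assay on MT4 cells (Homo sapiens) for activation, read by MTT assay (a lower number here means that less compound is tolerated, a higher number that more compound is tolerated), compound 1 `O=c1cc(Cc2c(F)cccc2Cl)nc(SC2CCCC2)[nH]1` gives > 74000 nM, which is a limit and not a number. Compound 2 `CCCCSc1nc(Cc2c(F)cccc2Cl)c(C)c(=O)[nH]1` gives > 73000 nM, which is also only a limit. Compound 2 therefore has no exact value, and the only other result available is a limit too. Compound 3 `Cc1c(Cc2c(F)cccc2Cl)nc(SC2CCCC2)[nH]c1=O` has cyclopentyl in place of butyl on a sulfur. Among the measured compounds shown here, no measured step between compounds guides this change, so no shift beyond the scatter is expected in this assay. The estimated change is an at least 1.0-fold lower number from compound 2 to compound 3 (0.00 log units; that floor lies within the scatter). The expected value for compound 3 is 72000 nM, with an estimated range of 40000 nM to 150000 nM.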

Compound 3, half-maximal cytotoxic concentration: > 71000 nM
Compound 3 ended at the assay's limit; the forecaster's own chance of this, stated with the estimate: 80%; the middle value lies beyond the limit too.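

Compound 1, compound 2 and compound 3 all stand as limits in this assay, and neither step to compound 3 can be read. From the compounds shown here alone, whether cyclopentyl in place of butyl, or methyl in place of hydrogen, shifts the cytotoxic concentration stays open.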